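Solubility notes on a sulfonamide series: compound 4

The source may hold more compounds than are shown below. What is called first, only, known or untested is meant among the compounds shown, and "the series" means these compounds.

Measured so far:
Compound 1, `O=C(c1cccc(Cl)c1)N1CCC(NS(=O)(=O)c2cc(S(=O)(=O)c3ccccc3)ccc2C(F)(F)F)CC1`: 6300 nM
Compound 2, `CC(C)(C)OC(=O)N1CCC(C(=O)N2CCC(NS(=O)(=O)c3cc(S(=O)(=O)c4ccccc4)ccc3C(F)(F)F)CC2)CC1`: 25000 nM
Compound 3, `CC(C)(C)OC(=O)N1CCC(CC(=O)N2CCC(NS(=O)(=O)c3cc(S(=O)(=O)c4ccccc4)ccc3C(F)(F)F)CC2)CC1`: 12500 nM

Three compounds sharing one core have numbers in a physicochemical assay for solubility; on this read-out higher numbers stand for higher solubility and lower numbers for lower solubility. Compound 1 stands at the low end of the three; compound 3 lies within the scatter of compound 1, while compound 2 lies beyond it, a clear step upward. Compound 2 and compound 3 both carry a tert-butoxycarbonyl-bearing saturated ring on the carbonyl carbon where compound 1 carries a chlorophenyl ring.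

Compound 4, `CC(C)(C)OC(=O)N1CC[C@@H](C(=O)N2CCC(NS(=O)(=O)c3cc(S(=O)(=O)c4ccccc4)ccc3C(F)(F)F)CC2)C1`, has not been measured in this assay. Relative to compound 1 it differs as follows: 1-(tert-butoxycarbonyl)pyrrolidin-3-yl in place of 3-chlorophenyl on a carbonyl carbon. Going by the values given here, no direct step between measured compounds matches this change, so what the measured pairs show is only that compound 2 and compound 3, each with a related entering group, give higher numbers than compound 1, one of them beyond the scatter.

On that basis an upward step from compound 1 to compound 4 is expected, of a size beyond the scatter, nearer to what compound 2 shows than to compound 3. The estimated step is a 3.2-fold higher number from compound 1 to compound 4 (0.50 log units; beyond the scatter). Compound 4 is expected to give 20000 nM in this assay, with a range from 8000 nM to 50000 nM.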

Compound 4, solubility: 12500 nM
Estimate against measurement, compound 4: 1.6-fold (0.20 log units) above; measured number inside the range.
By their numbers in this assay, from the lowest: compounds 1, 3, 4 and 2 (each within the scatter of the next, the first and the last beyond it).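

In this assay, placing 1-(tert-butoxycarbonyl)pyrrolidin-3-yl in place of 3-chlorophenyl on a carbonyl carbon gives a 2.0-fold higher number from compound 1 to compound 4 (0.30 log units; within the scatter), so this change does not clearly separate compound 4 from compound 1. Among the earlier compounds, the group in compound 2 stood beyond the scatter of compound 1 and the group in compound 3 did not; compound 4 now joins compound 3, which shows that a tert-butoxycarbonyl-bearing saturated ring at this place does not by itself bring a step beyond the scatter. No measurement is available that would account for the difference between these entering groups.

The compounds shown leave open how this place reads with a free secondary amine in place of the tert-butoxycarbonyl-bearing nitrogen, or with a carboxylic acid on the five-membered ring. Also open, as far as these compounds go, is whether the opposite configuration at the defined stereocentre reads the same as compound 4, and whether an unsubstituted phenyl ring reads the same as the 3-chlorophenyl of compound 1.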